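Trimethoxyphenyl on the five-membered ring: compound 4

This account rests on a few compounds, and the source may have more. Where it says the series, first, only, none or still open, it means among the compounds named here.

Measured compounds:
Compound 1 `COc1ccc(-c2cn(-c3cccc(C(=O)/C=C/c4cc(OC)c(OC)c(OC)c4)c3)c(=O)[nH]2)cc1` in a functional assay on TK-10 cells (Homo sapiens) for inhibition (a lower number here means a stronger inhibitor of growth, a higher number a weaker inhibitor of growth), gives 3040 nM.
Compound 2 `COc1ccc(-c2cn(-c3cccc(C(=O)/C=C/c4ccc(O)c(OC)c4)c3)c(=O)[nH]2)cc1` in this assay gives 6080 nM.
Compound 3 `O=C(/C=C/c1cccc(O)c1)c1cccc(-n2cc(-c3ccccc3)[nH]c2=O)c1` in this assay gives "not determined" (no result reported).

Compound 1 shows the lowest of the two numbers in this assay; its nearest neighbour is compound 2, and the step of a 2.0-fold higher number from compound 1 to compound 2 (0.30 log units; within the scatter) lies within the scatter, so the two cannot be ordered. Compound 3 has no number in this assay and adds nothing to the comparison.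

Compound 4 `COc1cc(/C=C/C(=O)c2cccc(-n3cc(-c4cc(OC)c(OC)c(OC)c4)[nH]c3=O)c2)cc(OC)c1OC` differs from compound 1 in one place: 3,4,5-trimethoxyphenyl in place of 4-methoxyphenyl on an aromatic carbon. Among the compounds with values here, the change sits on the five-membered ring, away from the double-bonded chain where the only measured step, a 2.0-fold higher number from compound 1 to compound 2 (0.30 log units; within the scatter), was taken. Within the data shown here, that step therefore does not bear on the change to compound 4, and no measured pair probes the group on the five-membered ring. With nothing to point either way, the expected step of a 1.2-fold higher number from compound 1 to compound 4 (0.06 log units; within the scatter) is taken as none beyond the scatter, with a wide range to reflect the missing precedent. Compound 4 is thus expected to give about 3500 nM in this assay, with a range from 1000 nM to 12000 nM.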

Compound 4, concentration for 50% growth inhibition: 3000 nM
Compound 4: middle estimate off by 1.2-fold (0.07 log units), on the high side; low and high end bracket the measured number.
By their numbers in this assay, from the lowest: compounds 4, 1 and 2 (each within the scatter of the next, the first and the last beyond it).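

In this assay, the group on the aromatic carbon of the five-membered aromatic ring now has a measured step of its own, whereas the earlier step concerned only the aryl group on the double-bonded chain. Placing 3,4,5-trimethoxyphenyl there in place of 4-methoxyphenyl gives a 1.0-fold lower number from compound 1 to compound 4 (0.01 log units; within the scatter), so the number stays within the scatter even though the entering group has 12 heavy atoms against 8 and 3 hydrogen-bond acceptors against 1. No available evidence bears on why this change leaves the number within the scatter.

The compounds shown carry only methoxy-substituted phenyl groups with a number at this position, so it remains open whether a phenyl bearing an amine or a carboxylic acid, or a longer alkyl chain in place of the aromatic ring, would move the number beyond the scatter. Compound 3 has no number in this assay, so the unsubstituted phenyl at this position also remains unread.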